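A few compounds are considered here, and "the series" means these few. Any claim that something is new, unique, unknown or untested is made for them only; others in the source may bear on it.

Values from a functional assay on HCT-116 cells (Homo sapiens) for antiproliferative activity, read by MTT assay, with a stated time of 48 h (on this read-out higher numbers stand for weaker inhibition and lower numbers for stronger inhibition), follow
compound 1 `CCCCCCC(CCO)n1cnc2c(OC)ncnc21` gives > 50000 nM
compound 2 `CCCCCCCC(CCO)n1cnc2c(OC)ncnc21` gives 15300 nM
compound 3 `CCCCCCCCC(CCO)n1cnc2c(Cl)ncnc21` gives 1650 nM

Compound 1 has > 50000 nM, which is a limit and not a number. Compound 3 holds the lower of the two actual numbers, and compound 2 stands higher at 15300 nM.

Compound 4 `CCCCCCCCC(CCO)n1cnc2c(OC)ncnc21` keeps the chain of compound 3 and puts methoxy in place of chloro on an aromatic carbon. Among the measured compounds shown here, no measured step isolates this exchange. Compound 4 is instead the methoxy member of the series, one chain carbon beyond compound 2. For the measured compounds named here, the one measured step that bears on it is the chain step an at least 3.2-fold lower number from compound 1 to compound 2 (0.51 log units; beyond the scatter). Its size is open-ended because of the limit of > 50000 nM in this assay, at which 1 of the 3 values shown sits. Extending the chain once more from compound 2 should therefore lower the number, though probably not as far as compound 3 at 1650 nM. The expected change is a 3.0-fold higher number from compound 3 to compound 4 (0.48 log units; beyond the scatter), a move to a higher number. For compound 4 the estimated value is 5000 nM, with an expected range of 2000 nM to 14000 nM.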

Compound 4, half-maximal inhibitory concentration: 12800 nM
For compound 4 the middle estimate is 2.6-fold (0.41 log units) below the measured one; the measured number falls inside the stated range.
By their numbers in this assay, from the lowest: compound 3; then compounds 4 and 2 (each within the scatter of the next). At a limit, above all of these: compound 1.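

In this assay, methoxy in place of chloro on an aromatic carbon now stands as an exchange on its own, with the chain held fixed: a 7.8-fold higher number from compound 3 to compound 4 (0.89 log units; beyond the scatter). Among the methoxy members the further chain carbon does not separate the two values, a 1.2-fold lower number from compound 2 to compound 4 (0.08 log units; within the scatter), so the earlier chain step does not carry on here. Compound 1 stands at a limit and not a number, and the span an at least 3.9-fold lower number from compound 1 to compound 4 (0.59 log units; beyond the scatter) stays open-ended: the limit of > 50000 nM in this assay, at which 1 of the 4 values shown sits.

Among the compounds shown here, compound 3 is the only chloro member, so whether the same exchange reads alike at other chain lengths remains open. Also open, as far as these compounds go, is how an amine on that aromatic carbon, or a longer chain with either chloro or methoxy, would read.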